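Hydroxy for Methoxy in a Growth-Inhibition Series

The source may report more compounds than this note shows. Statements on the series, on what has been measured and on what is new or still open speak of the compounds shown alone.

Three compounds have been measured in a functional assay on SNB-75 cells (Homo sapiens) for inhibition, read by sulforhodamine B assay, with a stated time of 48 h; a higher number here means a weaker inhibitor of growth, a lower number a stronger inhibitor of growth:

compound 1, `COc1cc(-c2nn(-c3cccc(NC(=O)Nc4cc(C(F)(F)F)cc(C(F)(F)F)c4)c3)cc2-c2ccncc2)ccc1Cl`, in this assay compound 1 gives 858 nM
compound 2, `COc1cc(-c2nn(-c3cccc(NC(=O)Nc4ccc(Cl)c(Cl)c4)c3)cc2-c2ccncc2)ccc1Cl`, in this assay compound 2 gives 1050 nM
compound 3, `O=C(Nc1cccc(-n2cc(-c3ccncc3)c(-c3ccc(Cl)c(O)c3)n2)c1)Nc1ccc(Cl)c(Cl)c1`, in this assay compound 3 gives 1090 nM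

Compound 1 and compound 2 differ in their cores; the difference between the two cores is not broken down here, and their values in this assay lie within the usual scatter of each other. Compound 2 and compound 3 differ in one place, (hydrogen in place of methyl on an oxygen on an aromatic ring), and this gave a 1.0-fold higher number from compound 2 to compound 3 (0.02 log units; within the scatter).

Compound 4, `O=C(Nc1cccc(-n2cc(-c3ccncc3)c(-c3ccc(Cl)c(O)c3)n2)c1)Nc1cc(C(F)(F)F)cc(C(F)(F)F)c1`, has not yet been measured. Within the data shown here, it differs from compound 1 by hydrogen in place of methyl on an oxygen on an aromatic ring, the same change, made at the same place, as the one from compound 2 to compound 3. Because a 1.0-fold higher number from compound 2 to compound 3 (0.02 log units; within the scatter) stayed within the scatter, compound 4 is expected to land close to compound 1, with an estimated step of a 1.0-fold higher number from compound 1 to compound 4 (0.02 log units; within the scatter). For compound 4 the estimate in this assay is 900 nM, expected to fall between 450 nM and 1800 nM.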

Compound 4, concentration for 50% growth inhibition: 877 nM
Estimate against measurement, compound 4: 1.0-fold (0.01 log units) above; measured number inside the range.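

In this assay, replacing methoxy with hydroxy on the second core gives a 1.0-fold higher number from compound 1 to compound 4 (0.01 log units; within the scatter). Set beside the earlier pair, the change carries from one core to the other with the same outcome, which is no step that stands out from the scatter: the same change on two cores in this assay, a 1.0-fold higher number (0.02 log units; within the scatter) from compound 2 to compound 3 and a 1.0-fold higher number (0.01 log units; within the scatter) from compound 1 to compound 4, 1.0-fold (0.01 log units) apart, within the scatter of two such steps This does not show that hydroxy and methoxy are interchangeable in general, since it rests on only two pairs of compounds in one cell growth read-out, and it cannot say why the numbers stay so close or whether the same would hold on a more different core or in other cells.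

The compounds shown leave open whether a longer chain on that oxygen, such as ethoxy, or an amine in place of the hydroxy would give a step beyond the scatter. From the compounds shown here alone, all four compounds also keep the chloro group on that ring, so what happens when it is replaced, for example by a methyl or a nitrile, remains unknown here.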